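Swapping Phenoxy for Dimethylamino in a Cytotoxicity Series

The compounds below may be only part of what the source reports. "The series", "measured", "known", "first", "only" and "open" are said of these compounds alone.

Measured so far:
Compound 1, `COc1cc(C)cc(-c2nn(CC#N)cc2-c2ccc(-c3cccc(C(C)=O)c3)nc2)c1`, in a functional assay on SNB-19 cells (Homo sapiens) for cytotoxicity, read by sulforhodamine B assay, with a stated time of 48 h, tested at 0.001 uM (a lower number here means a stronger effect, a higher number a weaker effect of the compound at the concentration tested), gives 101%.
Compound 2, `Cc1cc(O)cc(-c2nn(CC#N)cc2-c2ccnc(-c3ccc(Oc4ccccc4)cc3)c2)c1`, in this assay gives 101%.

Compound 2 stands level with compound 1 at the digits shown; the two read-outs lie within the usual scatter of each other, so no order between them can be claimed. Both point to little effect on the cells at the concentration tested.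

Compound 3, `Cc1cc(O)cc(-c2nn(CC#N)cc2-c2ccnc(-c3ccc(N(C)C)cc3)c2)c1`, has not yet been measured in this assay. It differs from compound 2 in one place: dimethylamino in place of phenoxy on an aromatic carbon. Going by the values given here, no step between two measured compounds is available here, so nothing shows how such a change moves the read-out. Because compound 2 gives 101% and compound 1 gives 101%, compound 3 is expected to behave the same way, with an expected step of a number 1 percentage points lower from compound 2 to compound 3 (within the scatter) of none beyond the scatter. The estimate for compound 3 is 100%, expected to fall between 88% and 110%.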

Compound 3, a percentage reported as activity, at one concentration (the size of the read-out at that concentration, not a potency): 96%
Beside the measured number, compound 3's estimate is 4 percentage points above it; the measured number falls inside the stated range.
By their numbers in this assay, from the lowest: compounds 3, 1 and 2 (each within the scatter of the next).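

Going by these compounds alone, this is the first step between two measured compounds that differ in one place, so it gives the first direct reading for this position in this assay. Putting dimethylamino in place of phenoxy, on an aromatic carbon para to a large group, gives a number 5 percentage points lower from compound 2 to compound 3 (within the scatter). The six-membered aromatic ring of phenoxy can therefore be exchanged for a group with no ring without a shift beyond the scatter at this concentration, though no measurement here gives a reason for this result.

The compounds shown leave open whether any group at this place can bring the read-out down beyond the scatter at this concentration. A carboxylic acid or a longer chain such as butoxy, on the same aromatic carbon, would be a further test of that question.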